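From Ethylsulfonyl to Dimethylsulfamoyl: A Single Change

The source may hold more compounds than are shown below. What is called first, only, known or untested is meant among the compounds shown, and "the series" means these compounds.

Two measured compounds open the account. Compound 1 `COc1cc(C(C)C(=O)NCc2ccc(C(F)(F)F)nc2N2CCC(C)CC2)cc(OC)c1NS(C)(=O)=O` gives 1.6 nM in an assay on cells for antagonist activity at transient receptor potential cation channel subfamily V member 1 (Homo sapiens), read by FLIPR and calcium flux, with a stated time of 15 min; a higher number here means a weaker inhibitor, a lower number a stronger inhibitor. Compound 2 `CCS(=O)(=O)Nc1ccc(C(C)C(=O)NCc2ccc(C(F)(F)F)nc2N2CCC(C)CC2)cc1F` gives 4.4 nM in this assay, the higher of the two numbers; the gap to compound 1 lies beyond the scatter. Compound 3 `CC1CCN(c2nc(C(F)(F)F)ccc2CNC(=O)C(C)c2ccc(NS(=O)(=O)N(C)C)c(F)c2)CC1` is not yet measured. It differs from compound 2 in one place: dimethylamino in place of ethyl on a sulfonyl sulfur, so the ethylsulfonyl becomes a dimethylsulfamoyl and the (ethylsulfonyl)amino a (dimethylsulfamoyl)amino. Among the compounds with values here, no measured pair shows this change, so there is no step to lean on. The sulfonyl and the sulfonamide nitrogen stay as they are in compound 2, which gives 4.4 nM. On that basis a step no larger than the scatter is expected, with no clear direction. The expected step is a 1.1-fold higher number from compound 2 to compound 3 (0.06 log units; within the scatter). Compound 3 is therefore estimated at 5 nM, with a range from 1.5 nM to 15 nM.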

Compound 3, inhibition constant: 42 nM
Estimate against measurement, compound 3: 8.4-fold (0.92 log units) below; measured number above the stated range.
By their numbers in this assay, from the lowest: compound 1; then compound 2; then compound 3.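

Placing dimethylamino in place of ethyl on a sulfonyl sulfur gives a 9.5-fold higher number from compound 2 to compound 3 (0.98 log units; beyond the scatter) in this assay, so this position responds clearly to what it carries, even with the sulfonyl and the sulfonamide nitrogen unchanged. Compound 1 and compound 2 differ in more than one place and could not isolate this position; this single step now does, though one step makes no trend. Nothing among the data shown bears on why the number rises.

Open, from the compounds shown here alone, is whether a longer chain such as propyl on the same sulfur would stay close to compound 2, or whether a smaller amine such as methylamino would carry the same penalty as dimethylamino. Also open, going by these compounds, is whether the step would hold on the core of compound 1.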